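The compounds below may be only part of what the source reports. "The series", "measured", "known", "first", "only" and "open" are said of these compounds alone.

In a functional assay on MCF7 cells (Homo sapiens) for inhibition, read by MTT assay, with a stated time of 2 days (on this read-out lower numbers stand for stronger inhibition and higher numbers for weaker inhibition), compound 1 `Oc1ccc(/C=C/c2ccccc2O)cc1` gives 21 ug/mL and compound 2 `Nc1ccccc1/C=C/c1ccccc1O` gives 39 ug/mL as its nearest neighbour, the two lying within the scatter of each other. Compound 3 `Nc1ccccc1/C=C/c1ccc(O)cc1` gives 79 ug/mL and is the furthest from compound 1. Compound 4 `COc1ccc(/C=C/c2ccccc2O)cc1` is still unmeasured and differs from compound 1 by methyl in place of hydrogen on an oxygen on an aromatic ring in the form of methyl in place of hydrogen on an oxygen on an aromatic ring, which reads as hydroxy to methoxy. Within the data shown here, the one measured step that bears on this, a 3.8-fold higher number from compound 1 to compound 3 (0.58 log units; beyond the scatter) with amino in place of hydroxy on an aromatic carbon, is modest and beyond the scatter. Among the measured compounds shown here, it alters a different hydroxy from the one changed in compound 4, so it offers only a loose guide. For the measured compounds named here, no measured step covers a methoxy group. A small drift towards a higher number is therefore expected, but nothing beyond the scatter. The estimated step of a 1.2-fold higher number from compound 1 to compound 4 (0.08 log units; within the scatter) reflects that expectation. In this assay compound 4 is expected at 25 ug/mL with a range of 10 ug/mL to 60 ug/mL as the estimate.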

Compound 4, half-maximal inhibitory concentration: 17 ug/mL
Compound 4: middle estimate off by 1.5-fold (0.17 log units), on the high side; the measured number falls inside the stated range.
By their numbers in this assay, from the lowest: compounds 4, 1 and 2 (each within the scatter of the next, the first and the last beyond it); then compound 3.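

In this assay the change from hydroxy to methoxy gives a 1.2-fold lower number from compound 1 to compound 4 (0.09 log units; within the scatter), so at this position a methyl can take the place of the hydrogen on the oxygen with no shift that can be told from the scatter. Among these compounds, the earlier step, a 3.8-fold higher number from compound 1 to compound 3 (0.58 log units; beyond the scatter), concerned the other hydroxy, which makes compound 4 the first reading at this position, and its result does not follow the rise seen at that other hydroxy. Nothing measured here gives a reason for this result.

The compounds shown leave open whether a longer chain on this oxygen, such as ethyl or benzyl, would also leave the number in place. They also leave open how an amine or a carboxylic acid at this position would read, and whether methoxy at the other hydroxy would match compound 4.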